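The compounds below may be only part of what the source reports. "The series", "measured", "known", "first", "only" and "open" are said of these compounds alone.

For the measured compounds named here, compound 2 `O=C(NCc1cccc(Cn2cnc3ccccc32)c1)c1cc2ccccc2o1` gives 413 nM in an assay for inhibition of Indoleamine 2,3-dioxygenase 1 (Homo sapiens), read by HPLC, with a stated time of 48 h (on this read-out higher numbers stand for weaker inhibition and lower numbers for stronger inhibition), which places it at the highest number among the two compounds measured so far. Going by the values given here, its only neighbour is compound 1 `O=C(NCc1cccc(Cn2cnc3ccccc32)c1)c1cc(Br)c[nH]1`, which in this assay gives 16 nM; the step between them is a 26-fold higher number from compound 1 to compound 2 (1.41 log units; beyond the scatter).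

Compound 3 `O=C(NCc1cccc(Cn2cnc3ccccc32)c1)c1cc2ccccc2[nH]1` has not yet been measured. It differs from compound 2 in one place: 1H-indol-2-yl in place of 1-benzofuran-2-yl on a carbonyl carbon. The entering group keeps the same two fused rings as the group it replaces, but swaps the ring oxygen for a ring nitrogen bearing a hydrogen.

Among the compounds with values here, only one measured step bears on this change. That step, a 26-fold higher number from compound 1 to compound 2 (1.41 log units; beyond the scatter), replaced a five-membered ring whose nitrogen carries a hydrogen with the benzofuran and was large. Within the data shown here, compound 3 brings such a ring nitrogen back, so the expected direction is toward a lower number, though the added six-membered ring has no measured counterpart here and the size is uncertain.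

Compound 3 is therefore expected to fall at about 60 nM, between 15 nM and 250 nM, an expected step of a 6.9-fold lower number from compound 2 to compound 3 (0.84 log units; beyond the scatter).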

Compound 3, half-maximal inhibitory concentration: 72 nM
For compound 3 the middle estimate is 1.2-fold (0.08 log units) below the measured one, and the stated range covers the measured number.
By their numbers in this assay, from the lowest: compound 1; then compound 3; then compound 2.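

With the two fused rings kept and only the ring atom changed, the swap of 1-benzofuran-2-yl for 1H-indol-2-yl gives a 5.7-fold lower number from compound 2 to compound 3 (0.76 log units; beyond the scatter) in this assay, so at this place on the carbonyl carbon the ring oxygen and the ring nitrogen bearing a hydrogen are not interchangeable. Bringing that nitrogen back does not recover the whole gap, however: 1H-indol-2-yl in place of 4-bromo-1H-pyrrol-2-yl still gives a 4.5-fold higher number from compound 1 to compound 3 (0.65 log units; beyond the scatter), and this step changes both the bromine and the added six-membered ring, so it cannot be assigned to either one alone. Nothing measured here explains why these changes move the number.

The compounds shown leave open how a plain 1H-pyrrol-2-yl group without the bromine would compare, which would help separate the bromine's contribution from that of the six-membered ring. They also leave open whether the hydrogen on the ring nitrogen matters in itself, a question that a methyl group on that nitrogen of the 1H-indol-2-yl group could address.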